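Shortening the Ethyl Urea Chain to Methyl

The compounds below may be only part of what the source reports. "The series", "measured", "known", "first", "only" and "open" are said of these compounds alone.

compound 1 `CCNC(=O)Nc1ccc(C(C)CC)cc1` — 43000 nM
compound 2 `CCNC(=O)Nc1ccc(C(C)(C)C)cc1` — 16000 nM; 70 nM (2 entries)
compound 3 `CCNC(=O)Nc1ccc(C(C)C)cc1` — 35000 nM

In a functional assay on L1210 cells (Mus musculus) (a lower number here means a stronger inhibitor, a higher number a weaker inhibitor), compound 1 gives 43000 nM. Compound 3, in this assay, gives 35000 nM, and the step of a 1.2-fold lower number from compound 1 to compound 3 (0.09 log units; within the scatter) is within the scatter, so the two compounds read as alike; compound 1 therefore sits among the weaker inhibitors shown. Compound 2 has several entries in this assay that do not agree with one another (the several entries of compound 2 in this assay, 16000 nM; 70 nM (2 entries)), so it offers no single number for comparison.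

Compound 4 `CCC(C)c1ccc(NC(=O)NC)cc1` differs from compound 1 by hydrogen in place of methyl on a saturated chain carbon bound to an amide-type nitrogen. Within the data shown here, the one measured step, a 1.2-fold lower number from compound 1 to compound 3 (0.09 log units; within the scatter), removes a methyl on a saturated chain carbon two bonds along the chain from an aromatic carbon, a different place from the one changed here, and it stayed within the scatter. Among the measured compounds shown here, no measured pair removes a methyl from the carbon bound to the amide-type nitrogen. For the measured compounds named here, with no precedent pointing either way, the expectation for this assay is a step no larger than the scatter, a 1.0-fold higher number from compound 1 to compound 4 (0.02 log units; within the scatter). Compound 4 is estimated at 45000 nM, with the expected range from 15000 nM to 130000 nM.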

Compound 4, half-maximal inhibitory concentration: 62000 nM
Compound 4: the middle estimate sits 1.4-fold (0.14 log units) below what was measured, and the stated range covers the measured number.
By their numbers in this assay, from the lowest: compounds 3, 1 and 4 (each within the scatter of the next).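

Replacing the ethyl on the urea with methyl, which puts hydrogen in place of methyl on a saturated chain carbon bound to an amide-type nitrogen, gives in this assay a 1.4-fold higher number from compound 1 to compound 4 (0.16 log units; within the scatter), so compound 1 and compound 4 read as alike. The earlier step, a 1.2-fold lower number from compound 1 to compound 3 (0.09 log units; within the scatter), touched a different place, so only this result shows that, in this assay, the ethylamino and methylamino forms of the compound cannot be told apart. No measurement shown explains why this change leaves the number within the scatter.

A longer chain such as propyl, or a carboxylic acid or an amine at the end of this chain, remains open, so the compounds shown do not tell whether anything placed here can move the number beyond the scatter. The branched group of compound 2 also remains unplaced against compound 1, compound 3 and compound 4, as its values give no single number to compare: the several entries of compound 2 in this assay, 16000 nM; 70 nM (2 entries)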